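A few compounds are considered here, and "the series" means these few. Any claim that something is new, unique, unknown or untested is made for them only; others in the source may bear on it.

Measured compounds:
compound 1 `Cc1ccc(NC2=CC(=O)c3c(nc4n3[C@H]3OC[C@@H](O)[C@H]3OC4)C2=O)cc1C` — 4950 nM
compound 2 `CCc1ccc(NC2=CC(=O)c3nc4n(c3C2=O)[C@H]2OC[C@@H](O)[C@H]2OC4)cc1` — 960 nM
compound 3 `O=C1C=C(Nc2cccc(Cl)c2)C(=O)c2c1nc1n2[C@H]2OC[C@@H](O)[C@H]2OC1` — 4720 nM

In a functional assay on MCF7 cells (Homo sapiens) for inhibition, read by sulforhodamine B assay (on this read-out lower numbers stand for stronger inhibition and higher numbers for weaker inhibition), compound 1 gives the highest of the three numbers; compound 3 sits within the scatter of it, while compound 2 lies clearly lower. Within the data shown here, the only step between measured compounds that differ in one place, a 4.9-fold higher number from compound 2 to compound 3 (0.69 log units; beyond the scatter), exchanges one aryl group for another on the amine nitrogen. Compound 4 `CCCN(CCC)C1=CC(=O)c2c(nc3n2[C@H]2OC[C@@H](O)[C@H]2OC3)C1=O` differs from compound 1 in one place: dipropylamino in place of (3,4-dimethylphenyl)amino on a double-bonded ring carbon. Among the measured compounds shown here, no measured step trades an arylamino group for a dialkylamino one, so this change has no direct anchor in the data; the step is expected to be modest at most, a 1.2-fold higher number from compound 1 to compound 4 (0.08 log units; within the scatter). Compound 4 is therefore estimated at 6000 nM, with a range from 1500 nM to 25000 nM.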

Compound 4, half-maximal inhibitory concentration: > 16000 nM
Compound 4 ended at the assay's limit; the forecaster's own chance of this, stated with the estimate: 15%; middle value at least 2.6-fold (0.42 log units) from the limit.
By their numbers in this assay, from the lowest: compound 2; then compounds 3 and 1 (each within the scatter of the next). At a limit, above all of these: compound 4.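

In this assay compound 4 stands at a limit of the assay, not at a number: the limit of > 16000 nM in this assay, at which 1 of the 4 values shown sits. The earlier step only exchanged one arylamino group for another, whereas dipropylamino in place of (3,4-dimethylphenyl)amino on the double-bonded ring carbon gives an at least 3.2-fold higher number from compound 1 to compound 4 (0.50 log units; beyond the scatter). This position therefore does not tolerate every amino group equally, since this change removes both the aromatic ring and the amine hydrogen. The compounds shown leave open which of the two loses the activity: propylamino would keep the amine hydrogen without the ring, and N-methylanilino the ring without the hydrogen.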